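Swapping a dimethylamino Tail for Piperazine on a Cytotoxicity Readout

This account rests on a few compounds, and the source may have more. Where it says the series, first, only, none or still open, it means among the compounds named here.

Measured compounds:
- compound 1 `Cc1cc(/C=C/C#N)cc(C)c1Oc1cc(NCCN2CCN(C)CC2)nc(Nc2ccc(C#N)cc2)c1`: 7960 nM
- compound 2 `Cc1cc(/C=C/C#N)cc(C)c1Oc1cc(NCCN(C)C)nc(Nc2ccc(C#N)cc2)n1`: 3040 nM
- compound 3 `C=CCNc1cc(Oc2c(C)cc(/C=C/C#N)cc2C)nc(Nc2ccc(C#N)cc2)n1`: 3050 nM

These three compounds were tested in an ADME assay on MT4 cells (Homo sapiens) for cytotoxicity, read by MTT assay, with a stated time of 5 days; a higher number here means that more compound is tolerated, a lower number that less compound is tolerated. Compound 2 gives the lowest of the three numbers, 3040 nM. Compound 3 differs from compound 2 in one place. Compound 3 gives 3050 nM, and the step of a 1.0-fold higher number from compound 2 to compound 3 (0.00 log units; within the scatter) is within the scatter. Compound 1 differs from compound 2 in more than one place. Compound 1 gives 7960 nM, a higher number that lies beyond the scatter.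

The new compound 4 `Cc1cc(/C=C/C#N)cc(C)c1Oc1cc(NCCN2CCNCC2)nc(Nc2ccc(C#N)cc2)n1` differs from compound 2 by piperazin-1-yl in place of dimethylamino on a saturated chain carbon, two bonds along the chain from a nitrogen on an aromatic ring. Among the measured compounds shown here, no measured step exchanges one tail amine for another on the same core, so the only guide is the step from compound 2 to compound 3, which showed that removing the dimethylamino tail altogether left this assay unchanged. A change that keeps an amine in the same place is therefore expected to move the number little, with the step of a 1.3-fold higher number from compound 2 to compound 4 (0.12 log units; within the scatter) expected to stay within or close to the scatter. Compound 4 is accordingly estimated at 4000 nM, with a range from 2000 nM to 9000 nM.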

Compound 4, half-maximal cytotoxic concentration: 3650 nM
For compound 4 the middle estimate is 1.1-fold (0.04 log units) above the measured one, within the range that was stated.
By their numbers in this assay, from the lowest: compounds 2, 3 and 4 (each within the scatter of the next); then compound 1.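

In this assay, exchanging dimethylamino for piperazin-1-yl on this saturated chain carbon, two bonds along the chain from a nitrogen on an aromatic ring, gives a 1.2-fold higher number from compound 2 to compound 4 (0.08 log units; within the scatter), so a larger group containing a six-membered non-aromatic ring and a hydrogen-bond donor is told apart from dimethylamino by nothing in this read-out. The comparison with the vinyl group gives a 1.2-fold higher number from compound 3 to compound 4 (0.08 log units; within the scatter), which means that compounds 2, 3 and 4, which share one core, now form a set of three different tails whose numbers all lie within the scatter of one another. No measurement offers an explanation for this result.

The compounds shown leave open whether a tail of another kind, such as a carboxylic acid or morpholin-4-yl, or a longer chain carrying the piperazin-1-yl group, would also stay within the scatter on this core. They also leave open what a methyl group on the free piperazine nitrogen of compound 4 would do on its own, as compound 1 differs from compound 4 in more than one place and its number cannot be tied to any single feature.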